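Lengthening the ester chain one step further

This account rests on a few compounds, and the source may have more. Where it says the series, first, only, none or still open, it means among the compounds named here.

In a functional assay on the whole organism with Scenedesmus acutus as the target, with a stated time of 20 h (on this read-out higher numbers stand for weaker inhibition and lower numbers for stronger inhibition), compound 1 (`CCCOC(=O)c1cc(N2C(=O)C3=C(CCCC3)C2=O)ccc1Cl`) gives 661 nM and compound 2 (`CCCCOC(=O)c1cc(N2C(=O)C3=C(CCCC3)C2=O)ccc1Cl`) gives 7760 nM as the higher of the two numbers, so it is the weaker inhibitor here. Compound 3 (`CCCCCOC(=O)c1cc(N2C(=O)C3=C(CCCC3)C2=O)ccc1Cl`) changes the same chain again: methyl in place of hydrogen on a saturated chain carbon, four bonds along the chain from an oxygen next to a carbonyl group in the form of methyl in place of hydrogen on a saturated chain carbon, four bonds along the chain from an oxygen next to a carbonyl group. Among the compounds with values here, the only comparable measured step, three bonds along the chain, was large, with a 12-fold higher number from compound 1 to compound 2 (1.07 log units; beyond the scatter) on this read-out. One step sets no trend, but a further, probably smaller rise is expected, with an estimated 2.3-fold higher number from compound 2 to compound 3 (0.37 log units; beyond the scatter) in this assay overall. For compound 3 the expected value is 18000 nM with a range from 4000 nM to 80000 nM on this estimate.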

Compound 3, half-maximal inhibitory concentration: 5370 nM
Compound 3: the middle estimate sits 3.4-fold (0.53 log units) above what was measured, and the stated range covers the measured number.
By their numbers in this assay, from the lowest: compound 1; then compounds 3 and 2 (each within the scatter of the next).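

Adding the methyl four bonds along the chain from an oxygen next to a carbonyl group gives a 1.4-fold lower number from compound 2 to compound 3 (0.16 log units; within the scatter) in this assay, so unlike the previous extension, this one makes no change beyond the scatter. Compared with the shorter chain, there is still an 8.1-fold higher number from compound 1 to compound 3 (0.91 log units; beyond the scatter) in this read-out, so the higher number seen with compound 2 persists in compound 3. No measurement here explains this flat stretch.

From the compounds shown here alone, whether a longer chain stays at this level remains open. So does the effect of a chain ending in an amine or a carboxylic acid.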